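Ester-to-Ether Swap on a Shared Amide Scaffold

The compounds below may be only part of what the source reports. "The series", "measured", "known", "first", "only" and "open" are said of these compounds alone.

Compound 3 `CC(C)(C)OC(=O)c1cccc(NC(=O)C2CCCN(C(=O)c3cc(C(F)(F)F)cc(C(F)(F)F)c3)C2)c1` stands level with compound 1 `O=C(Nc1cccc(Oc2nccc(C(F)(F)F)c2Cl)c1)C1CCCN(C(=O)c2cc(C(F)(F)F)cc(C(F)(F)F)c2)C1` and compound 2 `COC(=O)c1cccc(NC(=O)C2CCCN(C(=O)c3cc(C(F)(F)F)cc(C(F)(F)F)c3)C2)c1` in an ADME assay on PC-3 cells (Homo sapiens) for cytotoxicity, read by WST assay, tested at 100 uM; on this read-out lower numbers stand for less inhibition and higher numbers for more inhibition at the one concentration tested (going by the name of the read-out): compound 3 gives 0%, compound 1 gives 0%, and compound 2 gives 0%. Every measured step was flat: no change at the digits printed from compound 1 to compound 2 (within the scatter), no change at the digits printed from compound 1 to compound 3 (within the scatter) and no change at the digits printed from compound 2 to compound 3 (within the scatter). Compound 4 `COc1cccc(NC(=O)C2CCCN(C(=O)c3cc(C(F)(F)F)cc(C(F)(F)F)c3)C2)c1` differs from compound 3 in one place: methoxy in place of tert-butoxycarbonyl on an aromatic carbon. The two steps that exchanged groups on this same aromatic carbon, and the one that exchanged the alkyl on the oxygen, all stayed within the scatter, so no step beyond the scatter is expected here either: no change at the digits printed from compound 3 to compound 4 (within the scatter). Compound 4 is therefore expected to give 0%, with a range from 0% to 10%.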

Compound 4, a percentage reported as inhibition, at one concentration (the size of the read-out at that concentration, not a potency): 0%
For compound 4 middle estimate and measured number coincide at the digits printed, within the range that was stated.
By their numbers in this assay, from the lowest: compounds 1, 2, 3 and 4 (each within the scatter of the next).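

In this assay methoxy reads flat against every group seen on this aromatic carbon, with no change at the digits printed from compound 3 to compound 4 (within the scatter) and no change at the digits printed from compound 2 to compound 4 (within the scatter) and no change at the digits printed from compound 1 to compound 4 (within the scatter) as the new steps. Methoxy is the smallest group seen here and carries no carbonyl, unlike the two esters, yet the reading holds. No evidence is available to explain this flat result. As far as these compounds go, whether an amine or a carboxylic acid on this carbon would also leave this assay unmoved stays open. So does the effect of replacing the trifluoromethyl groups elsewhere on the shared core.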